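The compounds below may be only part of what the source reports. "The series", "measured", "known", "first", "only" and "open" are said of these compounds alone.

- compound 1 `Nc1ccccc1NC(=O)c1ccc(CNC(=O)c2n[nH]cc2NC(=O)c2c(F)cccc2Cl)cc1`: 1200 nM
- compound 2 `Nc1ccccc1NC(=O)c1ccc(CNC(=O)c2n[nH]cc2NC(=O)c2ccccc2Cl)cc1`: 2110 nM

Among the measured compounds shown here, in a functional assay on A-375 cells (Homo sapiens) for inhibition, read by CCK-8 assay, with a stated time of 72 h (on this read-out higher numbers stand for weaker inhibition and lower numbers for stronger inhibition), compound 2 gives 2110 nM, and compound 1, the only other measured compound, lies within the scatter of it at 1200 nM. Compound 3 `Nc1ccccc1NC(=O)c1ccc(CNC(=O)c2n[nH]cc2NC(=O)c2ccccc2)cc1` changes compound 2 in one place: hydrogen in place of chloro on an aromatic carbon. For the measured compounds named here, one measured step bears on this, a 1.8-fold higher number from compound 1 to compound 2 (0.25 log units; within the scatter), which also puts hydrogen on an aromatic carbon, there in place of fluoro. A similarly small rise is therefore expected, probably not clearly beyond the scatter: a 1.3-fold higher number from compound 2 to compound 3 (0.12 log units; within the scatter). For compound 3 the estimated value is 2800 nM, with an expected range of 1100 nM to 7000 nM.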

Compound 3, half-maximal inhibitory concentration: 1590 nM
The estimate for compound 3 lay 1.8-fold (0.25 log units) above the measured number, and the stated range covers the measured number.
By their numbers in this assay, from the lowest: compounds 1, 3 and 2 (each within the scatter of the next).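

In this assay, taking the chloro off the ring leaves the number within the scatter (a 1.3-fold lower number from compound 2 to compound 3 (0.12 log units; within the scatter)). The phenyl compound also stays within the scatter of the 2-chloro-6-fluorophenyl compound (a 1.3-fold higher number from compound 1 to compound 3 (0.12 log units; within the scatter)), so among these compounds, a ring carrying neither halogen reads the same as one carrying either or both, whereas the earlier pair covered only the loss of fluoro. No measurement shown accounts for this. These compounds carry only halogen or hydrogen on this ring. On these data alone, whether an amine, a methoxy group or a carboxylic acid at this place would shift the number beyond the scatter remains open.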